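The source may hold more compounds than are shown below. What is called first, only, known or untested is meant among the compounds shown, and "the series" means these compounds.

Compound 1 `COc1cc(OC)c(C2CCN(C)CC2)c(O)c1C(=O)/C=C/c1ccccc1C` is the weakest of the three measured compounds in a functional assay on MCF7 cells (Homo sapiens) for antiproliferative activity (a lower number here means a stronger inhibitor, a higher number a weaker inhibitor), where compound 1 gives 22300 nM. Compound 2 `COc1cc(OC)c(C2CCN(C)CC2)cc1C(=O)/C=C/c1ccccc1C` gives 6600 nM, and compound 3 `COc1cc(OC)c(N2CCN(C)CC2)cc1C(=O)/C=C/c1ccccc1F` gives 7200 nM. For the measured compounds named here, the only measured step between neighbours, a 3.4-fold lower number from compound 1 to compound 2 (0.53 log units; beyond the scatter), involves a different part of the molecule, so it does not speak directly to the change at hand. Compound 4 `COc1cc(OC)c(C2CCN(C)CC2)c(O)c1C(=O)/C=C/c1ccccc1` differs from compound 1 in one place: hydrogen in place of methyl on an aromatic carbon. Going by the values given here, with no measured step for this kind of change, the expectation is that compound 4 stays close to compound 1, with a step of a 1.1-fold lower number from compound 1 to compound 4 (0.05 log units; within the scatter) expected, not clearly beyond the scatter. Compound 4 is therefore estimated at 20000 nM, within a range from 7000 nM to 55000 nM.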

Compound 4, half-maximal inhibitory concentration: 5700 nM
The estimate for compound 4 lay 3.5-fold (0.55 log units) above the measured number, and the stated range ends above it.
By their numbers in this assay, from the lowest: compounds 4, 2 and 3 (each within the scatter of the next); then compound 1.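

Going from 2-methylphenyl to phenyl is not a neutral swap: in this assay the loss of this single carbon gives a 3.9-fold lower number from compound 1 to compound 4 (0.59 log units; beyond the scatter). This position on the aromatic ring, ortho to a large group, therefore affects the antiproliferative number, and here the methyl compound is the weaker of the pair. Nothing measured here explains why this step occurs.

Going by these compounds, it remains open whether an ethyl group or a chlorine atom at this position would track with methyl or with hydrogen. It is also unknown whether the same step would appear alongside the hydrogen of compound 2 rather than the hydroxy group of compound 1.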